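A few compounds are considered here, and "the series" means these few. Any claim that something is new, unique, unknown or untested is made for them only; others in the source may bear on it.

Values so far in a functional assay on U-251 cells (Homo sapiens) for antiproliferative activity, read by MTT assay, with a stated time of 48 h (a higher number here means a weaker inhibitor, a lower number a stronger inhibitor), are:
- compound 1 `COc1cccc(-c2nc3cccc(-c4cc(OC)c(OC)c(OC)c4)c3o2)c1` with > 25000 nM as a limit of the assay
- compound 2 `COc1ccc(-c2nc3cccc(-c4cc(OC)c(OC)c(OC)c4)c3o2)cc1OC` with 1300 nM as measured
- compound 3 `COc1cc(-c2cccc3nc(-c4ccc(Cl)cc4)oc23)cc(OC)c1OC` with 1600 nM as measured

Compound 3 at 1600 nM stands level with compound 2 at 1300 nM on these numbers. The gap is a 1.2-fold higher number from compound 2 to compound 3 (0.09 log units; within the scatter) and sets no order between them.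

Compound 4 `COc1cc(-c2nc3cccc(-c4cc(OC)c(OC)c(OC)c4)c3o2)ccc1O` carries 4-hydroxy-3-methoxyphenyl in place of 4-chlorophenyl on an aromatic carbon, next to the ring nitrogen and next to the ring oxygen, which gives 4-hydroxy-3-methoxyphenyl in place of 4-chlorophenyl on an aromatic carbon as the counted change.

All measured steps fall at this same group. Changes there can be large, as an at least 19-fold lower number from compound 1 to compound 2 (1.28 log units; beyond the scatter) and an at least 15-fold lower number from compound 1 to compound 3 (1.19 log units; beyond the scatter) show, yet a 1.2-fold higher number from compound 2 to compound 3 (0.09 log units; within the scatter) stays small although the groups differ. The group of compound 4 has a hydroxy where the 3,4-dimethoxyphenyl of compound 2 has a methoxy, so a value near that of compound 2 at 1300 nM is expected, with a wide range. No change beyond the scatter is expected, the estimated move being a 1.1-fold higher number from compound 3 to compound 4 (0.05 log units; within the scatter) at the middle. For compound 4 the expected value is 1800 nM, estimated to lie between 400 nM and 10000 nM in a repeat.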

Compound 4, half-maximal inhibitory concentration: 10300 nM
Estimate against measurement, compound 4: 5.7-fold (0.76 log units) below; the measured number lies above the stated range.
By their numbers in this assay, from the lowest: compounds 2 and 3 (each within the scatter of the next); then compound 4. At a limit, above all of these: compound 1.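

In this assay, methyl to hydrogen on an oxygen on the aromatic ring gives a 7.9-fold higher number from compound 2 to compound 4 (0.90 log units; beyond the scatter), so this place responds to a single methoxy-to-hydroxy change, whereas the 3,4-dimethoxyphenyl and 4-chlorophenyl groups of compound 2 and compound 3 gave values within the scatter. Replacing 4-chlorophenyl with 4-hydroxy-3-methoxyphenyl gives a 6.4-fold higher number from compound 3 to compound 4 (0.81 log units; beyond the scatter), so the level shared by compound 2 and compound 3 does not extend to this hydroxy-bearing group. Hydroxy in place of hydrogen on the aromatic carbon gives an at least 2.4-fold lower number from compound 1 to compound 4 (0.38 log units; beyond the scatter), a step that is only a bound, since compound 1 stands at a limit: the limit of > 25000 nM in this assay, at which 1 of the 4 values shown sits.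

The compounds shown leave open whether the methoxy of compound 4 is needed alongside its hydroxy. They also leave open how an amine or a carboxylic acid on this phenyl ring would compare with the hydroxy.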